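The source may hold more compounds than are shown below. What is called first, only, known or untested is meant among the compounds shown, and "the series" means these compounds.

Compound 1 `C=C(C)CCC[C@]1(C)C2=CCC[C@](C)(C[C@@H](OC(C)=O)C3=CC(=O)OC3O)[C@H]2CC[C@H]1C` and compound 3 `C=C(C)CC[C@]1(C)C2=CCC[C@](C)(C[C@@H](OC(C)=O)C3=CC(=O)OC3O)[C@H]2CC[C@H]1C` share a core and differ in one place only: 1-methylethenyl in place of 2-methylprop-2-en-1-yl on a saturated chain carbon, two bonds along the chain from a saturated ring carbon. In a functional assay on HT-29 cells (Homo sapiens) for antiproliferative activity, read by XTT assay, with a stated time of 72 h (a lower number here means a stronger inhibitor, a higher number a weaker inhibitor), compound 1 gives 2900 nM, and compound 3 gives 4800 nM, a step of a 1.7-fold higher number from compound 1 to compound 3 (0.22 log units; within the scatter). Compound 2 `C=C(C)CCC[C@]1(C)C2=CCC[C@](C)(C[C@H](O)C3=CC(=O)OC3O)[C@H]2CC[C@H]1C` carries a hydroxyl where compound 1 carries an acetate; the difference between these two cores is not broken down here. In this assay compound 2 gives 3000 nM. Compound 4 `C=C(C)CC[C@]1(C)C2=CCC[C@](C)(C[C@H](O)C3=CC(=O)OC3O)[C@H]2CC[C@H]1C` stands to compound 2 as compound 3 stands to compound 1, the same change: 1-methylethenyl in place of 2-methylprop-2-en-1-yl on a saturated chain carbon, two bonds along the chain from a saturated ring carbon. Among the measured compounds shown here, because the first instance of this change gave a 1.7-fold higher number from compound 1 to compound 3 (0.22 log units; within the scatter), the step from compound 2 to compound 4 is expected to be about a 1.6-fold higher number from compound 2 to compound 4 (0.20 log units; within the scatter). Compound 4 is therefore estimated at 4800 nM, with a likely range from 2500 nM to 9500 nM.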

Compound 4, half-maximal inhibitory concentration: 3200 nM
Beside the measured number, compound 4's estimate is 1.5-fold (0.18 log units) above it; measured number inside the range.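

In this assay, putting 1-methylethenyl in place of 2-methylprop-2-en-1-yl on the hydroxyl core gives a 1.1-fold higher number from compound 2 to compound 4 (0.03 log units; within the scatter), and the two instances of this change agree: the same change on two cores in this assay, a 1.7-fold higher number (0.22 log units; within the scatter) from compound 1 to compound 3 and a 1.1-fold higher number (0.03 log units; within the scatter) from compound 2 to compound 4, 1.6-fold (0.19 log units) apart, within the scatter of two such steps

Across these two pairs, the change carries from one core to the other without a detectable difference, and neither step moves the number beyond the usual scatter. This does not show that the change has no effect at all, since a small real effect could be hidden in the scatter, and two pairs say nothing about other cores or other assays.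

The compounds shown leave open what a longer chain would do at this place, or an amine or a carboxylic acid carried on the chain.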